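Chain extension on the diacetate core toward 5-lipoxygenase

A few compounds are considered here, and "the series" means these few. Any claim that something is new, unique, unknown or untested is made for them only; others in the source may bear on it.

Three compounds have numbers in an assay on isolated protein for inhibition of Polyunsaturated fatty acid 5-lipoxygenase (Homo sapiens), read by ELISA, with a stated time of 10 min; a lower number here means a stronger inhibitor, a higher number a weaker inhibitor. Compound 1 `CCCCCC1=CC(=O)C=C(OC)C1=N` gives 1010 nM. Compound 2 `CCCCCCCCCCCc1cc(O)cc(OC)c1O` gives 280 nM. Compound 3 `CCCCCc1cc(OC(C)=O)cc(OC)c1OC(C)=O` gives 1090 nM and stands highest of the three: its gap to compound 1 lies within the scatter, while compound 2 sits lower by a gap beyond the scatter, though compound 2 differs from compound 3 in more than one place.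

Compound 4 `CCCCCCCCCCCCCc1cc(OC(C)=O)cc(OC)c1OC(C)=O` is not yet measured; it carries octyl in place of hydrogen on a saturated chain carbon, five bonds along the chain from an aromatic carbon. The step from compound 3 to compound 4 is expected to lower the number moderately, a 2.7-fold lower number from compound 3 to compound 4 (0.44 log units; beyond the scatter), because compound 2 gives 280 nM with the longest chain among the measured set. For compound 4 the expected value is 400 nM, with a range from 150 nM to 1100 nM.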

Compound 4, half-maximal inhibitory concentration: 1020 nM
Compound 4: the middle estimate sits 2.6-fold (0.41 log units) below what was measured, and the stated range covers the measured number.
By their numbers in this assay, from the lowest: compound 2; then compounds 1, 4 and 3 (each within the scatter of the next).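

Octyl in place of hydrogen on a saturated chain carbon, five bonds along the chain from an aromatic carbon, gives a 1.1-fold lower number from compound 3 to compound 4 (0.03 log units; within the scatter) in this assay. For the compounds shown here, this is the first pair to differ in one place, and it shows that, on the shared core with both acetate groups kept, this chain extension does not move the number beyond the scatter. Nothing at hand explains this flat step.

The compounds shown leave open how a carboxylic acid or an amine at the end of the chain would read on this core. They also leave open whether the same extension would give a different step with free hydroxyl groups in place of the acetates.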